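Working notes: a methyl added to compound 3

The source may report more compounds than this note shows. Statements on the series, on what has been measured and on what is new or still open speak of the compounds shown alone.

Measured in a functional assay on HCT-116 cells (Homo sapiens) for antiproliferative activity, read by MTT assay, with a stated time of 48 h; on this read-out lower numbers stand for stronger inhibition and higher numbers for weaker inhibition:
- Compound 1 `CCCCCC(CCO)n1cnc2c(NC)ncnc21`: > 50000 nM, a limit and not a number
- Compound 2 `CCCCCCC(CCO)n1cnc2c(Cl)ncnc21`: 11900 nM
- Compound 3 `CCCCCCC(CCO)n1c(Br)nc2c(Cl)ncnc21`: 16100 nM

Within the data shown here, only two of these values are numbers, and compound 3 stands within the scatter of compound 2. Compound 4 `CCCCCCCC(CCO)n1c(Br)nc2c(Cl)ncnc21` differs from compound 3 by methyl in place of hydrogen on a saturated chain carbon, seven bonds along the chain from an aromatic nitrogen. Among the measured compounds shown here, no measured step changes the chain alone. For the measured compounds named here, the one measured step, a 1.4-fold higher number from compound 2 to compound 3 (0.13 log units; within the scatter), puts bromo in place of hydrogen on an aromatic carbon, so it bears only indirectly. Going by the values given here, with that small step as the sole guide, compound 3 at 16100 nM serves as the anchor, and no shift beyond the scatter is expected in this assay. The expected change is a 1.2-fold lower number from compound 3 to compound 4 (0.06 log units; within the scatter). The estimate for compound 4 is 14000 nM, with an estimated range of 6000 nM to 32000 nM.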

Compound 4, half-maximal inhibitory concentration: 16200 nM
Compound 4: the middle estimate sits 1.2-fold (0.06 log units) below what was measured; low and high end bracket the measured number.
By their numbers in this assay, from the lowest: compounds 2, 3 and 4 (each within the scatter of the next). At a limit, above all of these: compound 1.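

In this assay, the chain now has a measured step of its own: a 1.0-fold higher number from compound 3 to compound 4 (0.00 log units; within the scatter). With the bromo kept in place, methyl in place of hydrogen on a saturated chain carbon, seven bonds along the chain from an aromatic nitrogen, therefore stays within the scatter. Compound 1 alone rests on a limit, which is not a number: the limit of > 50000 nM in this assay, at which 1 of the 4 values shown sits.

From the compounds shown here alone, whether a longer chain, or an amine in place of this methyl, would move the number beyond the scatter remains open. So does whether this methyl gives the same result without the bromo.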